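This account rests on a few compounds, and the source may have more. Where it says the series, first, only, none or still open, it means among the compounds named here.

Compound 1 `Cn1c(N)c(-c2nc3ccccc3[nH]2)c2nc(C#N)c(C#N)nc21` gives > 50000 nM in a functional assay on cells (Homo sapiens) for antiproliferative activity, read by MTT assay, with a stated time of 48 h (on this read-out higher numbers stand for weaker inhibition and lower numbers for stronger inhibition), a limit of the assay rather than a number.
Compound 2 `CCn1c(N)c(-c2nc3ccccc3[nH]2)c2nc(C#N)c(C#N)nc21` gives > 50000 nM in this assay, again a limit.
Compound 3 `CCN(CC)CCn1c(N)c(-c2nc3ccccc3[nH]2)c2nc(C#N)c(C#N)nc21` gives 25400 nM in this assay.

Compound 2 therefore stands at the limit of the assay, with no number of its own, and it shares that position with compound 1, as the limit of > 50000 nM in this assay, at which 2 of the 3 values shown sit, records. The step that the two limits leave unreadable from compound 1 to compound 2, so it cannot be read. For the measured compounds named here, the one readable step from compound 2 is an at least 1.9-fold lower number from compound 2 to compound 3 (0.29 log units; that floor lies within the scatter); its floor lies within the scatter, so only a modest gain can be claimed for it.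

Compound 4 `CN1CCN(CCCn2c(N)c(-c3nc4ccccc4[nH]3)c3nc(C#N)c(C#N)nc32)CC1` differs from compound 2 by (4-methylpiperazin-1-yl)methyl in place of hydrogen on a saturated chain carbon, two bonds along the chain from an aromatic nitrogen. This is the same place on the saturated chain at which compound 3 carries its diethylamino group, now bearing a group that contains a six-membered non-aromatic ring with two hetero atoms. Going by the values given here, the step from compound 2 to compound 3 is the only measured guide, and it points to a lower number of at least modest size. The step of an at least 2.5-fold lower number from compound 2 to compound 4 (0.39 log units; beyond the scatter) is therefore expected to be a drop of roughly that order, not clearly beyond the scatter. Compound 4 is estimated at 20000 nM, within a range from 7000 nM to 55000 nM.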

Compound 4, half-maximal inhibitory concentration: 4520 nM
For compound 4 the middle estimate is 4.4-fold (0.65 log units) above the measured one; measured number below the stated range.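

For the compounds shown here, at the saturated chain carbon, two bonds along the chain from an aromatic nitrogen, the (4-methylpiperazin-1-yl)methyl group gives the first steps in this short series that lie beyond the scatter in this assay, with an at least 11-fold lower number from compound 2 to compound 4 (1.04 log units; beyond the scatter) and, measured from the shorter chain, an at least 11-fold lower number from compound 1 to compound 4 (1.04 log units; beyond the scatter). Both figures are floors rather than full sizes, and the real distance may be larger: the limit of > 50000 nM in this assay, at which 2 of the 4 values shown sit.

Going by these compounds alone, the earlier compounds showed only that a diethylamino group at this place gave a number of its own, whereas a 5.6-fold lower number from compound 3 to compound 4 (0.75 log units; beyond the scatter) now shows that what is attached there can move the result well beyond the scatter.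

That last step changes the chain and the amine together, from a 2-(diethylamino)ethyl to a 3-(4-methylpiperazin-1-yl)propyl group, so the compounds shown cannot divide the gain between the extra chain carbon and the ring. A 3-(diethylamino)propyl chain would speak to the first of these, while a piperidine or morpholine ring on the same propyl chain would show whether the second ring nitrogen and its methyl group matter.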